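Difluoromethyl in place of hydroxyethyl on a sulfonamide nitrogen

The source may report more compounds than this note shows. Statements on the series, on what has been measured and on what is new or still open speak of the compounds shown alone.

Compound 1 `COCCN(c1ccc(Cl)cc1C)S(=O)(=O)c1cc(Cl)ccc1Cl`: in an ADME assay on A549 cells (Homo sapiens) for cytotoxicity, read by MTT assay (on this read-out lower numbers stand for higher toxicity in this test and higher numbers for lower toxicity in this test), compound 1 gives > 5000 nM, a limit of the assay.
Compound 2 `Cc1cc(Cl)ccc1N(CCO)S(=O)(=O)c1cc(Cl)ccc1Cl`: in this assay compound 2 gives > 5000 nM, also a limit.

Compound 2 thus stands only at a limit, not at a number. For the measured compounds named here, the single measured step, a step that the two limits leave unreadable from compound 1 to compound 2, is unreadable because the limit of > 5000 nM in this assay, at which 2 of the 2 values shown sit, holds for both compounds. Compound 3 `Cc1cc(Cl)ccc1N(C(F)F)S(=O)(=O)c1cc(Cl)ccc1Cl` carries difluoromethyl in place of 2-hydroxyethyl on a sulfonamide nitrogen. No readable step bears on this change, so no direction beyond the scatter is expected. Compound 3 is estimated at 6000 nM, within 2500 nM to 20000 nM, and the expected step is a step that the limit leaves unreadable from compound 2 to compound 3.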

Compound 3, half-maximal cytotoxic concentration: > 5000 nM
Compound 3 ended at the assay's limit; the forecaster's own chance of this, stated with the estimate: 75%; the middle value is on the limit's open side.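

For the compounds shown here, no step from compound 1 or compound 2 to compound 3 can be read, because all three compounds share one limit: the limit of > 5000 nM in this assay, at which 3 of the 3 values shown sit.
Whether the 2-methoxyethyl, 2-hydroxyethyl and difluoromethyl groups of these compounds differ at all in this assay stays open.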